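The compounds below may be only part of what the source reports. "The series", "measured", "known", "first", "only" and "open" are said of these compounds alone.

Of the compounds shown here, three have been measured in an ADME assay on PANC-1 cells (Homo sapiens) for cytotoxicity, read by sulforhodamine B assay, with a stated time of 48 h, tested at 10 uM; on this read-out lower numbers stand for less inhibition and higher numbers for more inhibition at the one concentration tested (going by the name of the read-out). Compound 1 `COc1nc2ccc(Br)cc2cc1C(c1ccccc1)n1cc(-c2ccc(Br)cc2)nn1` gives 10.4%, compound 2 `COc1nc2ccc(Br)cc2cc1C(c1ccccc1)n1cc(-c2ccccc2)nn1` gives 30.1%, and compound 3 `CCOC(=O)c1cn(C(c2ccccc2)c2cc3cc(Br)ccc3nc2OC)nn1` gives 15.4%. Compound 2 therefore stands highest of the three: the step of a number 19.7 percentage points higher from compound 1 to compound 2 (beyond the scatter) and the step of a number 14.7 percentage points lower from compound 2 to compound 3 (beyond the scatter) both lie beyond the scatter, while the step of a number 5 percentage points higher from compound 1 to compound 3 (within the scatter) does not.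

Compound 4 `COc1nc2ccc(Br)cc2cc1C(c1ccccc1)n1cc(-c2ccccc2C(F)(F)F)nn1` is the unmeasured compound. It differs from compound 2 in one place: trifluoromethyl in place of hydrogen on an aromatic carbon.

Within the data shown here, two measured steps bear on this change. The step of a number 19.7 percentage points higher from compound 1 to compound 2 (beyond the scatter) shows that removing a bromo from the six-membered ring of carbon only raised inhibition, so the bare phenyl of compound 2 reads higher than its bromo-bearing counterpart. The step of a number 14.7 percentage points lower from compound 2 to compound 3 (beyond the scatter) shows that replacing that phenyl altogether lowered inhibition. Adding a trifluoromethyl to the same ring is the reverse direction of the first of these steps, though at a different place on the ring, so a modest fall in this assay is expected, possibly no larger than the scatter. For compound 4 the expected value is 20%, between 5% and 38%, an expected step of a number 10.1 percentage points lower from compound 2 to compound 4 (beyond the scatter).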

Compound 4, a percentage reported as inhibition, at one concentration (the size of the read-out at that concentration, not a potency): 11.4%
Compound 4: middle estimate off by 8.6 percentage points, on the high side, within the range that was stated.
By their numbers in this assay, from the lowest: compounds 1, 4 and 3 (each within the scatter of the next); then compound 2.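

Putting a trifluoromethyl on an aromatic carbon of the phenyl ring, ortho to a large group, gives in this assay a step of a number 18.7 percentage points lower from compound 2 to compound 4 (beyond the scatter) and so shows that this second kind of substitution on the ring also goes with a lower number, as the bromo of compound 1 did at its own place. The new compound also falls in with the other two, with a number 4 percentage points lower from compound 3 to compound 4 (within the scatter) and a number 1 percentage points higher from compound 1 to compound 4 (within the scatter), so among these four compounds the unsubstituted phenyl of compound 2 alone stands apart, while the bromo-bearing ring, the ethoxycarbonyl and the 2-(trifluoromethyl)phenyl cannot be told apart. No measurement shown here accounts for the fall seen with the trifluoromethyl.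

From the compounds shown here alone, it remains open whether the lower number belongs to trifluoromethyl itself or to any group at this place, which a methyl, a methoxy, an amine or a carboxylic acid on the same carbon could help to settle. Going by these compounds, it also remains open whether a trifluoromethyl on another carbon of this ring would read the same.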